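A few compounds are considered here, and "the series" means these few. Any claim that something is new, unique, unknown or untested is made for them only; others in the source may bear on it.

Working notes on the series. Of the compounds shown here, three sharing one core have been measured in an assay for inhibition of Dihydrofolate reductase (Bos taurus), at pH 7.20; on this read-out lower numbers stand for lower potency and higher numbers for higher potency (the scale is a negative logarithm). Compound 1 `CC1(C)N=C(N)N=C(N)N1c1ccccc1N` gives 4.58. Compound 2 `CSc1ccccc1N1C(N)=NC(N)=NC1(C)C` gives 3.91, the lowest of the three numbers. Compound 3 `CC1(C)N=C(N)N=C(N)N1c1ccccc1Cl` gives 5.19, the highest. The step of a number 0.67 log units lower from compound 1 to compound 2 (beyond the scatter) runs downward from the amino compound to the methylsulfanyl compound. The step of a number 0.61 log units higher from compound 1 to compound 3 (beyond the scatter) and the step of a number 1.28 log units higher from compound 2 to compound 3 (beyond the scatter) both point upward from the amino and methylsulfanyl compounds toward the chloro compound.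

Compound 4 `CC1(C)N=C(N)N=C(N)N1c1ccccc1C(F)(F)F` has not been measured. Its change from compound 2: trifluoromethyl in place of methylsulfanyl on an aromatic carbon. For the measured compounds named here, no measured step involves a trifluoromethyl, so the bearing of the known steps is indirect; both departures from methylsulfanyl seen so far, to amino and to chloro, raised the number in this assay, the latter by a large margin. A rise is therefore expected for compound 4, of the order of a number 1.09 log units higher from compound 2 to compound 4 (beyond the scatter), though the absence of a direct precedent widens the range. The estimate for compound 4 in this assay is 5, between 4.3 and 5.7.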

Compound 4, logarithm of the reciprocal of the active concentration, log(1/C): 3.53
Beside the measured number, compound 4's estimate is 1.47 log units above it; the measured number lies below the stated range.
By their numbers in this assay, from the lowest: compound 4; then compound 2; then compound 1; then compound 3.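

Trifluoromethyl on this aromatic carbon gives the first number under that of methylsulfanyl in this assay, with a number 0.38 log units lower from compound 2 to compound 4 (beyond the scatter) and so a new low end for the four groups. The larger falls, a number 1.05 log units lower from compound 1 to compound 4 (beyond the scatter) and a number 1.66 log units lower from compound 3 to compound 4 (beyond the scatter), show that replacing amino or chloro with trifluoromethyl here is far from neutral, and that methylsulfanyl and trifluoromethyl both sit under amino and chloro. No supporting measurement bears on why the number falls with this change.

From the compounds shown here alone, it remains open whether methyl, methoxy or bromo at this place would fall with the low pair or with amino and chloro. A fluoro or hydroxy group would likewise show how far the order of these four groups extends.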